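The compounds below may be only part of what the source reports. "The series", "measured", "known", "first", "only" and "open" are said of these compounds alone.

Compound 1, with the structure `CCN1CCN(C(=S)SCC(O)Cn2c([N+](=O)[O-])cnc2C)CC1`, was tested in a toxicity assay on HeLa cells (Homo sapiens) for cytotoxicity, read by MTT assay, with a stated time of 24 h; on this read-out higher numbers stand for weaker inhibition and lower numbers for stronger inhibition. In this assay compound 1 gives > 5000000 nM, which is a limit of the assay rather than a measured number. Compound 2, with the structure `Cc1ncc([N+](=O)[O-])n1CC(O)CSC(=S)N1CCN(c2ccccc2)CC1`, differs from compound 1 by a phenyl in place of ethyl on an amine nitrogen in a ring. In this assay compound 2 gives > 5000000 nM, again a limit of the assay. The step that the two limits leave unreadable from compound 1 to compound 2 therefore cannot be read in size or direction. Among the compounds with values here, compound 1 thus stands only at a limit, and the one further value shown sits at the same limit, namely (the limit of > 5000000 nM in this assay, at which 2 of the 2 values shown sit).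

Compound 3, with the structure `Cc1ncc([N+](=O)[O-])n1CC(O)CSC(=S)N1CCC(C)CC1`, has not yet been measured. It differs from compound 1 in one place: 4-methylpiperidin-1-yl in place of 4-ethylpiperazin-1-yl on a thiocarbonyl carbon. Within the data shown here, no measured step bears directly on a change of this kind, and the only step available is unreadable, so no size or direction beyond the scatter can be drawn from the data. For compound 3 the expected value in this assay is estimated at 8000000 nM, with a range from 3000000 nM to 30000000 nM. The estimated step that the limit leaves unreadable from compound 1 to compound 3 reflects an expectation that a limit is again the most likely outcome.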

Compound 3, half-maximal inhibitory concentration: 1820000 nM
For compound 3 the middle estimate is 4.4-fold (0.64 log units) above the measured one; measured number outside the range, below it.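

Within the data shown here, compound 3 is the first compound here to give a measured number rather than a limit: the limit of > 5000000 nM in this assay, at which 2 of the 3 values shown sit.

In this assay, the swap on a thiocarbonyl carbon gives an at least 2.7-fold lower number from compound 1 to compound 3 (0.43 log units; beyond the scatter), so the group at this place can move the read-out towards stronger inhibition, whereas the earlier step, phenyl in place of ethyl, cannot be read. The swap makes two changes at once, carbon taking the place of a ring nitrogen and methyl taking the place of ethyl, and the step belongs to the two together, not to either one alone.

The compounds shown therefore leave open which of the two changes matters, a question that 4-ethylpiperidin-1-yl or 4-methylpiperazin-1-yl at the same place could settle, since each would make only one of them. They also leave open whether other groups on the thiocarbonyl carbon, such as morpholin-4-yl or a piperidine ring with a longer chain, would shift the number further in the same direction or return it to the limit.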